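This account rests on a few compounds, and the source may have more. Where it says the series, first, only, none or still open, it means among the compounds named here.

Of the compounds shown here, three sharing one core have been tested in an ADME assay on HEK293 cells (Homo sapiens) for cytotoxicity, read by CellTiter-Glo and resazurin assay, with a stated time of 72 h; on this read-out higher numbers stand for an effect only at larger amounts of compound and lower numbers for an effect already at smaller amounts. Compound 1 `CC(C)N(Cc1cccc(OCCCCCC(=O)O)c1)C(=O)c1ccc(-c2ccncc2)cc1` carries a pyridin-4-yl group. In this assay compound 1 reached only the limit of > 26000 nM. Compound 2 `CC(C)N(Cc1cccc(OCCCCCC(=O)O)c1)C(=O)c1ccc(-c2cccc(-c3ccccc3)c2)cc1` carries a 3-phenylphenyl group instead. In this assay compound 2 likewise reached only the limit of > 26000 nM. Compound 3 `COc1cccc(-c2ccc(C(=O)N(Cc3cccc(OCCCCCC(=O)O)c3)C(C)C)cc2)c1` carries a 3-methoxyphenyl group. In this assay compound 3 also reached only the limit of > 20900 nM. The steps a step that the two limits leave unreadable from compound 1 to compound 2, a step that the two limits leave unreadable from compound 1 to compound 3 and a step that the two limits leave unreadable from compound 2 to compound 3 cannot be read because the limit of > 26000 nM in this assay, at which 2 of the 3 values shown sit, and the limit of > 20900 nM in this assay, at which 1 of the 3 values shown sits, give ceilings rather than numbers. Compound 3 therefore stands among values that are all limits, with no number of its own to compare.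

Compound 4 `CC(C)N(Cc1cccc(OCCCCCC(=O)O)c1)C(=O)c1ccc(-c2c[nH]c3ccccc23)cc1` differs from compound 3 in one place: 1H-indol-3-yl in place of 3-methoxyphenyl on an aromatic carbon. For the measured compounds named here, no measured step shows how a 1H-indol-3-yl group behaves in this assay, and the steps touching compound 3 are unreadable, so no shift beyond the scatter is expected. For compound 4 the estimated value is 26000 nM, with a range from 10000 nM to 60000 nM, most probably again a limit. The expected step is a step that the limit leaves unreadable from compound 3 to compound 4.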

Compound 4, half-maximal effective concentration: > 26000 nM
Compound 4 ended at the assay's limit (the forecaster's own chance of this, stated with the estimate: 75%); the middle value sits exactly at the limit.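

Compound 4 also ended at a limit rather than a number, so its steps from compound 1, compound 2 and compound 3 cannot be read. The compounds shown leave open at what concentration any of these four would show an effect in this assay.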